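A few compounds are considered here, and "the series" means these few. Any claim that something is new, unique, unknown or untested is made for them only; others in the source may bear on it.

Measured in an ADME assay on CEM-SS cells (Homo sapiens) for cytotoxicity, read by XTT assay, with a stated time of 6 days; a higher number here means that more compound is tolerated, a lower number that less compound is tolerated:
- compound 1 `CCCC(=O)OCSc1ccccc1C(=O)NCC(N)=O`: > 100 uM
- compound 2 `CCCC(=O)OCSc1ccccc1C(=O)N[C@@H]1CCC[C@H]1C(N)=O`: 43.7 uM

Not yet measured:
- compound 3 `CCCC(=O)OCSc1ccccc1C(=O)N(C)CC(N)=O`

Compound 1 stands at the limit of > 100 uM in this assay, at which 1 of the 2 values shown sits. Its value is a limit of the assay and not a number.

Compound 3 differs from compound 1 by methyl in place of hydrogen on an amide-type nitrogen. For the measured compounds named here, only one measured step bears on this change: an at least 2.2-fold lower number from compound 1 to compound 2 (0.35 log units; beyond the scatter). That step swaps a different group on an amide-type nitrogen, so it offers only loose guidance. In this assay, a modest lowering or no change beyond the scatter is therefore expected, and compound 3 may well report only a limit too. The step expected is an at least 1.1-fold lower number from compound 1 to compound 3 (0.07 log units; that floor lies within the scatter). The estimate for compound 3 is 85 uM, with an expected range of 35 uM to 200 uM.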

Compound 3, half-maximal toxic concentration: 55.3 uM
Compound 3: middle estimate off by 1.5-fold (0.19 log units), on the high side, within the range that was stated.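

Working notes on the amide-type nitrogen: in this assay, methyl in place of the amide hydrogen is a change of a single carbon, yet compound 3 reads 55.3 uM as a number, so a number at this nitrogen does not require a group as large as the 2-carbamoylcyclopentyl of compound 2. Compound 1 gives > 100 uM, which is a limit and not a number. As far as these compounds go, the change reads as an at least 1.8-fold lower number from compound 1 to compound 3 (0.25 log units; that floor lies within the scatter), and its full size stays unknown because compound 1 supplies no number: the limit of > 100 uM in this assay, at which 1 of the 3 values shown sits.

Open, from the compounds shown here alone, is whether ethyl or a longer chain on this nitrogen would move the number further than methyl. Also open, going by these compounds, is whether methyl has the same effect when the carbamoylmethyl group is replaced by a carboxylic acid or an amine.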